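A change on the amide nitrogen of a weak inhibitor

The source may report more compounds than this note shows. Statements on the series, on what has been measured and on what is new or still open speak of the compounds shown alone.

Compound 1 `CCOC(=O)C1=Cc2ccccc2OC1(OCc1cn(CC(=O)Nc2ccccc2Br)nn1)C(F)(F)F` was tested in a functional assay on DU-145 cells (Homo sapiens) for inhibition, read by MTT assay, with a stated time of 24 h; a higher number here means a weaker inhibitor, a lower number a stronger inhibitor. In this assay compound 1 gives > 150000 nM, which is a limit of the assay rather than a number. For the measured compounds named here, the only other measured compound, compound 2 `CCOC(=O)C1=Cc2ccccc2OC1(OCc1cc(-c2cccc(C(F)(F)F)c2)no1)C(F)(F)F`, gives 57300 nM in this assay. Going by the values given here, compound 1 therefore sits at the limit of > 150000 nM in this assay, at which 1 of the 2 values shown sits, and no step between two measured compounds is available to guide the next move. Compound 3 `CCOC(=O)C1=Cc2ccccc2OC1(OCc1cn(CC(=O)Nc2ccc(OC)cc2)nn1)C(F)(F)F` differs from compound 1 in one place: 4-methoxyphenyl in place of 2-bromophenyl on an amide-type nitrogen. With nothing measured to lean on, one expects this change to shift this assay by no more than the usual scatter, so that compound 3 most likely stays at or near the limit seen for compound 1. The step expected here is a number no higher from compound 1 to compound 3 (the limit leaves the size open). Compound 3 is thus estimated at 150000 nM in this assay, with a range from 60000 nM to 400000 nM.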

Compound 3, half-maximal inhibitory concentration: 32700 nM
Compound 3: middle estimate off by 4.6-fold (0.66 log units), on the high side, and the stated range ends above it.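

In this assay, 4-methoxyphenyl in place of 2-bromophenyl on the amide-type nitrogen gives an at least 4.5-fold lower number from compound 1 to compound 3 (0.66 log units; beyond the scatter). For the compounds shown here, this is the first sign that the group on this nitrogen matters to the read-out, and that a compound with this side chain on the shared core can give a measurable number rather than a limit. The step has only a lower bound on its size, as the value of compound 1 is a limit of the assay and not a number: the limit of > 150000 nM in this assay, at which 1 of the 3 values shown sits.

The change swaps the bromine for a methoxy group and alters the group's place together, so the two cannot be told apart from these compounds. From the compounds shown here alone, how a plain phenyl, or a phenyl carrying an amine or a carboxylic acid, would read on this nitrogen remains open.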